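This account rests on a few compounds, and the source may have more. Where it says the series, first, only, none or still open, it means among the compounds named here.

Measured so far in an assay on blood for inhibition of Indoleamine 2,3-dioxygenase 1 (Homo sapiens), read by mass spectrometry, with a stated time of 18 h; a higher number here means a weaker inhibitor, a lower number a stronger inhibitor:

Compound 1 `CCC(c1nc2ncc(Cl)cc2[nH]1)[C@H]1CC[C@@H](c2ccnc3ccc(C(F)(F)F)cc32)CC1` gives 21 nM.
Compound 2 `C[C@@H](c1nc2ncc(Cl)cc2[nH]1)[C@H]1CC[C@@H](c2ccnc3ccc(F)cc32)CC1` gives 26 nM.
Compound 3 `CCOCC(Nc1nnc(-c2ccc(OC)cc2)o1)[C@H]1CC[C@@H](c2ccnc3ccc(C(F)(F)F)cc32)CC1` gives 96 nM.

Compound 1 holds the lowest of the three numbers in this assay. The gap to compound 2 is within the usual scatter, so the two cannot be told apart on these data; the gap to compound 3 is beyond the scatter, so compound 1 is the stronger inhibitor of that pair.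

The next compound, compound 4 `CCC(c1nc2ncc(Cl)cc2[nH]1)[C@H]1CC[C@@H](c2ccnc3ccc(F)cc32)CC1`, comes from compound 1 by one change: fluoro in place of trifluoromethyl on an aromatic carbon. The rest of the molecule, including the fused bicyclic ring bearing the chloro group and the linking chain with its cyclohexyl, is unchanged. Going by the values given here, no measured pair in this set differs by exactly this change, so its size must be judged indirectly. Compound 2 carries the same fluoro group at the same position as compound 4, together with a shorter chain, and in this assay compound 2 gives 26 nM, a number within the scatter of compound 1. Among the compounds with values here, that is the only guide available.

The step from compound 1 to compound 4 is expected to be small, a 1.2-fold higher number from compound 1 to compound 4 (0.08 log units; within the scatter), with no direction beyond the scatter. Compound 4 is therefore estimated at 25 nM in this assay, in the range 10 nM to 60 nM.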

Compound 4, half-maximal inhibitory concentration: 6 nM
Estimate against measurement, compound 4: 4.2-fold (0.62 log units) above, outside the stated range (below it).
By their numbers in this assay, from the lowest: compound 4; then compounds 1 and 2 (each within the scatter of the next); then compound 3.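

Notes on the series: in this assay, this aromatic carbon, meta to a fused ring and para to a fused ring, now has its first single-change reading, a 3.5-fold lower number from compound 1 to compound 4 (0.54 log units; beyond the scatter), and that step is beyond the scatter. The position therefore responds to its substituent, even though the exchange of trifluoromethyl (4 heavy atoms) for fluoro (1 heavy atom) involves no hydrogen-bond donors or acceptors on either side, no ring and no net charge; in this one pair, the group with fewer heavy atoms carries the lower number. No evidence bearing on this step is available. The result stands as an observation on a single pair.

Going by these compounds, a single pair gives no trend at this carbon, so it remains open how bare hydrogen, a nitrile or an amine would compare there with fluoro and trifluoromethyl. Going by these compounds alone, it also remains open whether the same exchange would give a step of similar size on a longer chain in place of the one shared by compound 1 and compound 4.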